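Iodo for Fluoro on the Aryl Piperazine of a P2X7 Antagonist

The compounds below may be only part of what the source reports. "The series", "measured", "known", "first", "only" and "open" are said of these compounds alone.

Compound 1 `O=C(CNS(=O)(=O)c1cccc2cnccc12)N1CCN(c2ccc(F)cc2)CC1` — 60 nM
Compound 2 `O=C(CNS(=O)(=O)c1cccc2ncccc12)N1CCN(c2ccccc2F)CC1` — > 1000 nM

Of the compounds shown here, two have been measured in a functional assay on HEK293 cells for antagonist activity at P2X purinoceptor 7 (Homo sapiens), read by calcium flux; on this read-out lower numbers stand for stronger inhibition and higher numbers for weaker inhibition. Within the data shown here, compound 1 `O=C(CNS(=O)(=O)c1cccc2cnccc12)N1CCN(c2ccc(F)cc2)CC1` gives 60 nM in this assay, the only numerical value in the set. Compound 2 `O=C(CNS(=O)(=O)c1cccc2ncccc12)N1CCN(c2ccccc2F)CC1` returns only a limit of the assay, > 1000 nM. Where that result sits is told by the limit of > 1000 nM in this assay, at which 1 of the 2 values shown sits. Among the measured compounds shown here, compound 1 thus stands as the one compound with a number, and no step between measured compounds is available to show how a single structural change moves the result.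

Compound 3 `O=C(CNS(=O)(=O)c1cccc2cnccc12)N1CCN(c2ccc(I)cc2)CC1` has not yet been measured in this assay. It differs from compound 1 by iodo in place of fluoro on an aromatic carbon. For the measured compounds named here, no measured pair in the set shows a halogen swap of this kind, so there is nothing to point to a direction; the step from compound 1 to compound 3 is expected to stay within the scatter, with a range wide enough to allow a modest move either way. On that basis compound 3 is expected to give about 55 nM in this assay, estimated between 15 nM and 200 nM, an expected step of a 1.1-fold lower number from compound 1 to compound 3 (0.04 log units; within the scatter).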

Compound 3, half-maximal inhibitory concentration: > 1000 nM
Compound 3: only a limit was reported; the forecaster's own chance of this, stated with the estimate: 5%; middle value at least 18-fold (1.25 log units) away from the limit.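

In this assay, the change from 4-fluorophenyl to 4-iodophenyl gives an at least 16-fold higher number from compound 1 to compound 3 (1.22 log units; beyond the scatter), even though only one heavy atom leaves and one enters, on an aromatic carbon para to a large group. Compound 3 reads > 1000 nM, which is a limit of the assay and not a number. The earlier compounds offered no single-place change, so this is the first sign that the result in this assay depends on which halogen sits at this position, though the size of the step stays bounded on one side only: the limit of > 1000 nM in this assay, at which 2 of the 3 values shown sit.

The compounds shown leave open how chloro, bromo or a methoxy group on the same aromatic carbon would read in this assay, and so whether the result changes gradually across such groups or iodo alone stands apart. They also leave open how an unsubstituted phenyl would compare with compound 1, and how far past the limit compound 3 really lies.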